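This account rests on a few compounds, and the source may have more. Where it says the series, first, only, none or still open, it means among the compounds named here.

Of the compounds shown here, three have been tested so far in an ADME assay on H9c2 cells (Rattus norvegicus) for cytotoxicity (on this read-out lower numbers stand for stronger inhibition and higher numbers for weaker inhibition), and none has yet given a readable number. Compound 1 `CC(C)(C)C(=O)Nc1nc2ccc(Cl)cc2s1` gives > 50000 nM, which is a limit and not a measured number. Compound 2 `O=C(Nc1nc2cc(F)c(C(F)(F)F)cc2s1)C1CC1` gives > 50000 nM, which is also a limit. Compound 3 `CC(C)C(=O)Nc1nc2cc(F)c(C(F)(F)F)cc2s1` gives > 50000 nM, again a limit, so compound 3 has no exact value of its own.

Compound 4 `CC(C)(F)C(=O)Nc1nc2cc(F)c(C(F)(F)F)cc2s1` is still unmeasured. Its structure differs from that of compound 3 by one change: fluoro in place of hydrogen on a saturated chain carbon bound to a carbonyl carbon and two saturated chain carbons. This turns isopropyl into 1-fluoro-1-methylethyl.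

Going by the values given here, only one measured step links two close relatives, and it is a step that the two limits leave unreadable from compound 2 to compound 3. It changes the same group on the carbonyl carbon, but it offers no size to carry over. Among the compounds with values here, the only other guide is the limit of > 50000 nM in this assay, at which 3 of the 3 values shown sit. No direction can be read from these results, so no step beyond the scatter is expected. The expected change is a number no higher from compound 3 to compound 4 (the limit leaves the size open), and this is only an estimate. In this assay the estimate for compound 4 is 50000 nM, with an expected range from 20000 nM to 100000 nM, and a report of the same limit is the likeliest outcome.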

Compound 4, half-maximal inhibitory concentration: > 50000 nM
Compound 4: a limit, no number (the forecaster's own chance of this, stated with the estimate: 85%); the middle value sits exactly at the limit.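

In this assay compound 4 gives > 50000 nM, which is again a limit and not a number. Going by these compounds alone, as a result, no step among compound 2, compound 3 and compound 4 can be read. The compounds shown leave open whether changing the group on the carbonyl carbon alters this read-out at all, because every result so far is a limit: the limit of > 50000 nM in this assay, at which 4 of the 4 values shown sit.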